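Dropping the phenyl methoxy from a cyanovinyl sulfone indole

The source may report more compounds than this note shows. Statements on the series, on what has been measured and on what is new or still open speak of the compounds shown alone.

The three measured compounds, all tested in a functional assay on HT-29 cells (Homo sapiens) for inhibition, read by sulforhodamine B assay, with a stated time of 48 h; a higher number here means a weaker inhibitor of growth, a lower number a stronger inhibitor of growth:

compound 1, `COc1ccc(-c2[nH]c3ccccc3c2/C=C(\C#N)S(=O)(=O)c2ccccc2)cc1`: 314 nM
compound 2, `COc1ccc2[nH]c(-c3ccccc3)c(C=C(C#N)C#N)c2c1`: 3100 nM
compound 3, `COc1ccc(-c2[nH]c3ccc(OC)cc3c2/C=C(\C#N)S(=O)(=O)c2ccccc2)cc1`: 435 nM

Compound 3 gives the second highest of the three numbers. Its nearest neighbour is compound 1, with a 1.4-fold higher number from compound 1 to compound 3 (0.14 log units; within the scatter) between them, a gap that lies within the scatter. Compound 2 stands much further away, with a clearly higher number.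

Compound 4, `COc1ccc2[nH]c(-c3ccccc3)c(/C=C(\C#N)S(=O)(=O)c3ccccc3)c2c1`, differs from compound 3 in one place: hydrogen in place of methoxy on an aromatic carbon. Cut one bond further out, this reads as 4-methoxyphenyl to phenyl.

For the measured compounds named here, only one measured step bears on a methoxy change, and it concerns the other methoxy: a 1.4-fold higher number from compound 1 to compound 3 (0.14 log units; within the scatter) was within the scatter. Compound 2, which shares the unsubstituted phenyl of compound 4 but carries a different vinyl group, cannot be compared directly. Removing a methoxy from the phenyl is therefore expected to move the number little, perhaps slightly upward, with a 1.1-fold higher number from compound 3 to compound 4 (0.06 log units; within the scatter) as the estimated step; compound 4 is estimated at 500 nM, in a range from 200 nM to 1500 nM.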

Compound 4, concentration for 50% growth inhibition: 3500 nM
Compound 4: middle estimate off by 7.0-fold (0.85 log units), on the low side, outside the stated range (above it).
By their numbers in this assay, from the lowest: compounds 1 and 3 (each within the scatter of the next); then compounds 2 and 4 (each within the scatter of the next).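

In this assay the methoxy of the 4-methoxyphenyl group clearly counts: replacing it with hydrogen gives an 8.0-fold higher number from compound 3 to compound 4 (0.91 log units; beyond the scatter), so this group is tied to the stronger growth inhibition in this pair. The other methoxy, on the shared core, gave only a 1.4-fold higher number from compound 1 to compound 3 (0.14 log units; within the scatter), so the two methoxy groups do not count alike in this assay. Nothing available here explains why the change at this position has the larger effect.

Open, going by these compounds, is whether a hydroxyl, an ethoxy or a dimethylamino group at this same place would keep the lower number that methoxy gives. Also open, on these data alone, is whether losing this methoxy would cost as much on a core without the second methoxy.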